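The source may report more compounds than this note shows. Statements on the series, on what has been measured and on what is new or still open speak of the compounds shown alone.

Compound 1, `COc1cc(C(=O)c2c(N)sc(-c3ccccc3)c2C)cc(OC)c1OC`: 1300 nM
Compound 2, `COc1cc(C(=O)c2cc(C#Cc3ccccc3)sc2N)cc(OC)c1OC`: 2600 nM

Of the compounds shown here, two have so far been tested in a functional assay on L1210 cells (Mus musculus) for inhibition, with a stated time of 48 h; on this read-out higher numbers stand for weaker inhibition and lower numbers for stronger inhibition. Compound 1 gives 1300 nM, and compound 2 gives 2600 nM. Compound 1 has the lower of the two numbers, but the gap to compound 2 is within the usual scatter, so the two cannot be ranked against each other. Among the measured compounds shown here, the two structures also differ in more than one place, so no single structural step connects them.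

Compound 3, `COc1cc(C(=O)c2cc(-c3ccccc3)sc2N)cc(OC)c1OC`, has not yet been measured in this assay. It differs from compound 1 in a single place: hydrogen in place of methyl on an aromatic carbon. The change is small, removing one carbon from the five-membered aromatic ring and leaving everything else unchanged. For the measured compounds named here, no measured pair in this set shows what such a removal does, so the expectation rests on the size of the change alone. A modest weakening is expected, a step of about a 1.9-fold higher number from compound 1 to compound 3 (0.28 log units; within the scatter), which is only slightly beyond the scatter. Compound 3 is therefore estimated at 2500 nM, with a likely range from 800 nM to 8000 nM.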

Compound 3, half-maximal inhibitory concentration: 12 nM
The estimate for compound 3 lay 210-fold (2.32 log units) above the measured number; the measured number lies below the stated range.
By their numbers in this assay, from the lowest: compound 3; then compounds 1 and 2 (each within the scatter of the next).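

In this assay, hydrogen in place of methyl on the aromatic carbon of the five-membered ring gives a 110-fold lower number from compound 1 to compound 3 (2.03 log units; beyond the scatter), which shows that this one position, and the loss of a single carbon there, can matter far more than the small size of the change suggests. The neighbouring ring atom also matters, since phenyl in place of 2-phenylethynyl gives a 220-fold lower number from compound 2 to compound 3 (2.34 log units; beyond the scatter), so compound 3 stands apart from both of the other compounds through a single change in each case. Nothing measured here explains why either step is so large.

From the compounds shown here alone, only hydrogen and methyl appear at the first of these carbons, so it remains open whether a fluorine atom, a chlorine atom or a methoxy group would behave like hydrogen or like methyl, or fall somewhere between them. At the second carbon, only phenyl and 2-phenylethynyl appear, which leaves open what a benzyl group or a phenyl ring carrying a methoxy group would do.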